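The source may hold more compounds than are shown below. What is called first, only, known or untested is meant among the compounds shown, and "the series" means these compounds.

Measured compounds:
compound 1, `CCOC(=O)c1ccc(NC(=O)NCc2cocn2)cc1`, in an assay on isolated protein for activation of Nicotinamide phosphoribosyltransferase (Homo sapiens) (a higher number here means that more compound is needed for the effect, a lower number that less compound is needed), gives 27600 nM.
compound 2, `CCOC(=O)c1ccc(NC(=O)NCc2ccnnc2)cc1`, in this assay reaches only the limit > 100000 nM, which is a limit of the assay and not a number (the limit of > 100000 nM in this assay, at which 1 of the 3 values shown sits).
compound 3, `O=C(NCc1ccncc1)Nc1ccc(S(=O)(=O)NCc2ccccc2)cc1`, in this assay gives 102 nM.

Compound 3 holds the lowest of the two numbers recorded; the nearest, compound 1, stands far higher, and compound 2 gives only a limit. Among the compounds with values here, the one step with a single change is an at least 3.6-fold higher number from compound 1 to compound 2 (0.55 log units; beyond the scatter), a swap of the heteroaryl ring on the chain carbon, and it does not touch the sulfonamide end of the molecule.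

Compound 4, `NS(=O)(=O)c1ccc(NC(=O)NCc2ccncc2)cc1`, differs from compound 3 at that end: hydrogen in place of benzyl on a sulfonamide nitrogen. Within the data shown here, no measured step covers this change; compound 3 differs from compounds 1 and 2 in more than one place, so their values give no isolated reading of the sulfonamide substituent. The expectation rests therefore on the size of the group leaving alone, and a loss of potency is expected, of uncertain extent.

For compound 4 in this assay the expected step is a 15-fold higher number from compound 3 to compound 4 (1.17 log units; beyond the scatter). Compound 4 is estimated at 1500 nM, with a range from 250 nM to 10000 nM.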

Compound 4, half-maximal effective concentration: 14300 nM
Estimate against measurement, compound 4: 9.5-fold (0.98 log units) below; the whole stated range lies below it.
By their numbers in this assay, from the lowest: compound 3; then compounds 4 and 1 (each within the scatter of the next). At a limit, above all of these: compound 2.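

In this assay, within the data shown here, hydrogen in place of benzyl on a sulfonamide nitrogen gives a 140-fold higher number from compound 3 to compound 4 (2.15 log units; beyond the scatter) and is the first single change read at this end of the molecule. The earlier single-change step altered only the heteroaryl ring on the chain carbon, whereas this pair shows that potency also moves strongly with the substituent on the sulfonamide nitrogen, although that reading rests on compound 3 and compound 4 alone. The one available supporting observation concerns another compound's assay limit and gives no explanation for this step.

Going by these compounds, whether the gain with benzyl depends on its aromatic ring or on carbon substitution alone remains open, and methyl, cyclohexylmethyl or a longer chain such as 2-phenylethyl on the same nitrogen would separate those readings. Also open, on these data alone, is how far the benzyl ring tolerates further groups, such as an amine or a carboxylic acid, and whether the effect of the sulfonamide substituent carries over when the pyridin-4-yl ring is replaced by another heteroaryl ring.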